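Swapping the amide substituent for 2-carboxyethyl

This account rests on a few compounds, and the source may have more. Where it says the series, first, only, none or still open, it means among the compounds named here.

Compound 1 `CCn1c(C(=O)N[C@H](C)CO)ccc1C(CC)(CC)c1ccc(OCS(=O)(=O)c2ccccc2)c(C)c1` gives 10600 nM 
Compound 2 `CCn1c(C(=O)NCCCO)ccc1C(CC)(CC)c1ccc(OCS(=O)(=O)c2ccccc2)c(C)c1` gives 42000 nM 
Compound 3 `CCn1c(C(=O)N[C@H](CO)CCCO)ccc1C(CC)(CC)c1ccc(OCS(=O)(=O)c2ccccc2)c(C)c1` gives 31400 nM 

These values come from a functional assay on MCF7 cells (Homo sapiens) for antiproliferative activity, read by MTT assay, with a stated time of 24 h (a lower number here means a stronger inhibitor, a higher number a weaker inhibitor), and compound 4 `CCn1c(C(=O)NCCC(=O)O)ccc1C(CC)(CC)c1ccc(OCS(=O)(=O)c2ccccc2)c(C)c1` has yet to be measured there. Compound 1 is the most potent of the three. Compound 3 stands level with compound 2, since the step of a 1.3-fold lower number from compound 2 to compound 3 (0.13 log units; within the scatter) lies within the scatter. The step of a 3.0-fold higher number from compound 1 to compound 3 (0.47 log units; beyond the scatter) lies beyond it and sets both apart from compound 1.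

Compound 4 differs from compound 3 on the amide-type nitrogen: a group of 5 heavy atoms (3 carbon, 2 oxygen; no ring) in place of a group of 7 heavy atoms (5 carbon, 2 oxygen; no ring), on an amide-type nitrogen. A 2-carboxyethyl group enters there, and the defined stereocentre leaves with the old group. Among the compounds with values here, no measured compound carries 2-carboxyethyl, so the evidence is indirect. Three steps at the same nitrogen bear on the change. The step of a 4.0-fold higher number from compound 1 to compound 2 (0.60 log units; beyond the scatter) is modest, as is a 3.0-fold higher number from compound 1 to compound 3 (0.47 log units; beyond the scatter), while a 1.3-fold lower number from compound 2 to compound 3 (0.13 log units; within the scatter) stays within the scatter. Changes at this nitrogen have therefore moved the number only modestly, and compound 3 already lies at the high end of the series. No step beyond the scatter is expected in this assay, although a modest one in either direction remains possible. The estimated step is a 1.3-fold higher number from compound 3 to compound 4 (0.11 log units; within the scatter) on this reasoning. For compound 4 the expected value is 40000 nM, with an estimated range from 15000 nM to 90000 nM pending measurement.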

Compound 4, half-maximal inhibitory concentration: > 50000 nM
Compound 4 was reported as a limit; the forecaster's own chance of this, stated with the estimate: 20%; middle value at least 1.2-fold (0.09 log units) away from the limit.
By their numbers in this assay, from the lowest: compound 1; then compounds 3 and 2 (each within the scatter of the next). At a limit, above all of these: compound 4.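

In this assay compound 4 is reported as a limit and not as a number: the limit of > 50000 nM in this assay, at which 1 of the 4 values shown sits.
Against the group of compound 1, the step is clear: an at least 4.7-fold higher number from compound 1 to compound 4 (0.67 log units; beyond the scatter), so each of the three other groups on this amide-type nitrogen now gives a higher number than 1-(hydroxymethyl)ethyl, with no compound shown going against that, and 2-carboxyethyl does not bring the number back towards compound 1. Against the two other compounds the reading is weaker, since an at least 1.5-fold higher number from compound 3 to compound 4 (0.20 log units; that floor lies within the scatter) and an at least 1.1-fold higher number from compound 2 to compound 4 (0.07 log units; that floor lies within the scatter) both have floors within the scatter; carboxy in place of hydroxymethyl thus shows no separation from compound 2 that can be stated, only that the new group does not fall below the limit.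

What the compounds shown leave open is how an amine or a methyl ester at the end of the same chain would compare with the carboxylic acid, and whether a longer chain carrying that acid would read differently. Going by these compounds, the mirror-image form of 1-(hydroxymethyl)ethyl also stays open, as does the actual value of compound 4.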